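Fluoro and ester changes on a shared dione core

The source may hold more compounds than are shown below. What is called first, only, known or untested is meant among the compounds shown, and "the series" means these compounds.

Measured so far:
compound 1 `O=C(O)c1cc(N2C(=O)C3=C(CCCC3)C2=O)c(F)cc1Cl`, 759 nM
compound 2 `O=C(O)c1cc(N2C(=O)C3=C(CCCC3)C2=O)ccc1Cl`, > 100000 nM
compound 3 `CCC(C)OC(=O)c1cc(N2C(=O)C3=C(CCCC3)C2=O)ccc1Cl`, 794 nM

In a functional assay on the whole organism with Scenedesmus acutus as the target (a higher number here means a weaker inhibitor, a lower number a stronger inhibitor), compound 1 gives 759 nM. Compound 2 gives only a limit, namely (the limit of > 100000 nM in this assay, at which 1 of the 3 values shown sits). Compound 3 gives 794 nM, which is within the scatter of compound 1.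

Two changes start from compound 2. One is fluoro in place of hydrogen on an aromatic carbon, and it gives an at least 130-fold lower number from compound 2 to compound 1 (2.11 log units; beyond the scatter). The other is sec-butyl in place of hydrogen on an oxygen next to a carbonyl group, which is also how the core of compound 3 differs from that of compound 2, and it gives an at least 120-fold lower number from compound 2 to compound 3 (2.10 log units; beyond the scatter).

Compound 4 `CCC(C)OC(=O)c1cc(N2C(=O)C3=C(CCCC3)C2=O)c(F)cc1Cl` has not been measured. It differs from compound 3 by fluoro in place of hydrogen on an aromatic carbon. This is the same kind of change as that from compound 2 to compound 1, though here the place is para to a sec-butoxycarbonyl group rather than para to a carboxy group.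

On these data alone, because an at least 130-fold lower number from compound 2 to compound 1 (2.11 log units; beyond the scatter) starts from a limit, its true size is unknown, and compound 3 already sits far from that limit, so a smaller step is expected here: a 5.3-fold lower number from compound 3 to compound 4 (0.72 log units; beyond the scatter). For compound 4 the expected value in this assay is 150 nM, likely between 30 nM and 800 nM.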

Compound 4, half-maximal inhibitory concentration: 24.6 nM
Estimate against measurement, compound 4: 6.1-fold (0.79 log units) above; the measured number lies below the stated range.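

In this assay, fluoro in place of hydrogen on an aromatic carbon gives a 32-fold lower number from compound 3 to compound 4 (1.51 log units; beyond the scatter), so this change keeps its direction when carried to the sec-butyl ester, but its size is not shown to carry over: the same change on two cores in this assay, an at least 130-fold lower number (2.11 log units; beyond the scatter) from compound 2 to compound 1 and a 32-fold lower number (1.51 log units; beyond the scatter) from compound 3 to compound 4, at least 4.0-fold (0.61 log units) apart, beyond the scatter of two such steps

Sec-butyl in place of hydrogen on the oxygen of the carboxy group gives a 31-fold lower number from compound 1 to compound 4 (1.49 log units; beyond the scatter), so this change also keeps its direction on the fluoro-bearing core, again without a matching size: the same change on two cores in this assay, an at least 120-fold lower number (2.10 log units; beyond the scatter) from compound 2 to compound 3 and a 31-fold lower number (1.49 log units; beyond the scatter) from compound 1 to compound 4, at least 4.0-fold (0.61 log units) apart, beyond the scatter of two such steps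

Compound 2 gives only a limit, so the true size of both earlier steps, and the full gap between each pair of steps, cannot be read: the limit of > 100000 nM in this assay, at which 1 of the 4 values shown sits.

The compounds shown leave open whether a bromo or methoxy group in place of the fluoro would have a comparable effect. They also leave open whether a methyl ester, a longer chain or an amide in place of the sec-butyl ester would follow the same direction.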